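Cytotoxicity in the benzyl-ether sultone series: compound 4

The source may hold more compounds than are shown below. What is called first, only, known or untested is meant among the compounds shown, and "the series" means these compounds.

Measured compounds:
compound 1 `CCC1(Cc2ccccc2)OS(=O)(=O)C=C1OCc1ccc(OC)cc1`: >= 200000 nM
compound 2 `CCC1(Cc2ccccc2)OS(=O)(=O)C=C1OCc1ccccc1Cl`: >= 20000 nM
compound 3 `CCC1(Cc2ccccc2)OS(=O)(=O)C=C1OCC=C(C)C`: 400000 nM

Among the compounds with values here, in an ADME assay on HEL cells (Homo sapiens) for cytotoxicity, with a stated time of 3 days (a lower number here means that less compound is tolerated, a higher number that more compound is tolerated), compound 3 gives 400000 nM, the only number so far. The value of compound 1 is a limit of this assay, (the limit of >= 200000 nM in this assay, at which 1 of the 3 values shown sits). The value of compound 2 is also a limit, (the limit of >= 20000 nM in this assay, at which 1 of the 3 values shown sits). The steps a step that the two limits leave unreadable from compound 1 to compound 2, a step that the limit leaves unreadable from compound 1 to compound 3 and a step that the limit leaves unreadable from compound 2 to compound 3 are therefore of unknown size.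

Compound 4 `CCC1(Cc2ccccc2)OS(=O)(=O)C=C1OCc1ccc(Br)cc1` differs from compound 3 by 4-bromophenyl in place of 2-methylprop-1-en-1-yl on a saturated chain carbon bound to an oxygen on an unsaturated carbon. Within the data shown here, compound 3 is the only measured compound with a chain at this place; compounds 1 and 2 carry an aryl group there, as compound 4 does. No readable step bears on the change, so no direction beyond the scatter can be set. Compound 4 is expected to sit near compound 3, with the step of a 2.0-fold lower number from compound 3 to compound 4 (0.30 log units; within the scatter), the estimate being 200000 nM in the range 50000 nM to 600000 nM.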

Compound 4, minimum cytotoxic concentration: 80000 nM
Beside the measured number, compound 4's estimate is 2.5-fold (0.40 log units) above it; the measured number falls inside the stated range.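

In this assay, two steps can now be read at this place: 4-bromophenyl in place of 2-methylprop-1-en-1-yl gives a 5.0-fold lower number from compound 3 to compound 4 (0.70 log units; beyond the scatter), and bromo in place of methoxy on an aromatic carbon gives an at least 2.5-fold lower number from compound 1 to compound 4 (0.39 log units; beyond the scatter), so both the swap from chain to aryl group and the swap of the group on the aromatic carbon can move the number beyond the scatter. The value of compound 1 is a limit: the limit of >= 200000 nM in this assay, at which 1 of the 4 values shown sits. The step from compound 2 to compound 4 cannot be read, and no measured property accounts for the readable steps.

With 2-methylprop-1-en-1-yl as the only chain shown, it remains open whether the lower number of compound 4 holds for aryl groups generally or belongs to 4-bromophenyl alone. A longer saturated chain, or a phenyl group carrying an amine or a carboxylic acid, at this place would bear on that question.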